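A Fluoro-to-Methyl Swap at the Assay Limit

A few compounds are considered here, and "the series" means these few. Any claim that something is new, unique, unknown or untested is made for them only; others in the source may bear on it.

In a functional assay on SK-OV-3 cells (Homo sapiens) for cytotoxicity, read by MTT assay, with a stated time of 24 h (on this read-out lower numbers stand for stronger inhibition and higher numbers for weaker inhibition), compound 1 (`O=Cc1cc2ccccc2n(Cc2ccccc2)c1=O`) gives > 100000 nM as a limit and not a number. Compound 2 (`C#CCn1c(=O)c(C=O)cc2cc(F)ccc21`) likewise gives > 100000 nM as a limit and not a number. The measured record is therefore the limit of > 100000 nM in this assay, at which 2 of the 2 values shown sit, and contains no numerical value. Compound 3 (`C#CCn1c(=O)c(C=O)cc2cc(C)ccc21`) carries methyl in place of fluoro on an aromatic carbon and is otherwise the same as compound 2. No change beyond the usual scatter is expected in this assay and the estimated move is a number no higher from compound 2 to compound 3 (the limit leaves the size open) in size. For compound 3 the estimate is 100000 nM with 40000 nM to 200000 nM as the expected range.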

Compound 3, half-maximal inhibitory concentration: > 100000 nM
Compound 3: no number, only a limit (the forecaster's own chance of this, stated with the estimate: 75%); the middle value lies on the limit itself.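

No step can be read from compound 2 to compound 3, as both values are limits and not numbers: the limit of > 100000 nM in this assay, at which 3 of the 3 values shown sit. The compounds shown leave open whether methyl in place of fluoro changes anything in this assay, and where any of the three compounds would give a number.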